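Lengthening the Amide Chain of a Methoxylated Aniline

The compounds below may be only part of what the source reports. "The series", "measured", "known", "first", "only" and "open" are said of these compounds alone.

Among the measured compounds shown here, compound 2 `COc1ccc(CN(C(C)=O)c2cc(OC)c(OC)c(OC)c2)cc1O` stands lowest of the three numbers measured so far: in a functional assay on HCT-116 cells (Homo sapiens) for inhibition, read by MTT assay, with a stated time of 48 h (a lower number here means a stronger inhibitor, a higher number a weaker inhibitor), compound 2 gives 270 nM. Compound 3 `COc1ccc(CNc2cc(OC)c(OC)c(OC)c2)cc1` gives 18400 nM, and compound 1 `COc1ccc(CNc2cc(OC)c(OC)c(OC)c2)cc1C` gives 60900 nM. For the measured compounds named here, the one measured step, a 3.3-fold lower number from compound 1 to compound 3 (0.52 log units; beyond the scatter), concerns hydrogen in place of methyl on an aromatic carbon and tells nothing about the amide side of the molecule. Compound 4 `C/C=C/C(=O)N(Cc1ccc(OC)c(O)c1)c1cc(OC)c(OC)c(OC)c1` differs from compound 2 by prop-1-en-1-yl in place of methyl on a carbonyl carbon, that is, acetyl to (prop-1-en-1-yl)carbonyl. Going by the values given here, no measured pair touches this part, so the expectation rests on compound 2 alone, and the step of a 1.1-fold higher number from compound 2 to compound 4 (0.05 log units; within the scatter) is expected to stay within the scatter. Compound 4 is therefore estimated at 300 nM, with a range from 80 nM to 1200 nM.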

Compound 4, half-maximal inhibitory concentration: 55 nM
The estimate for compound 4 lay 5.5-fold (0.74 log units) above the measured number, and the stated range ends above it.
By their numbers in this assay, from the lowest: compound 4; then compound 2; then compound 3; then compound 1.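

Among the compounds shown here, the carbonyl carbon of the amide responds to change: with prop-1-en-1-yl in place of methyl, this assay shows a 4.9-fold lower number from compound 2 to compound 4 (0.69 log units; beyond the scatter) as the first measured step on this side of the molecule. For the compounds shown here, the larger group, with its double bond outside aromatic rings, is therefore tolerated here and gives the lowest number so far. Nothing at hand explains this gain.

The compounds shown leave open whether the double bond or the added length matters. A saturated propyl chain on this carbonyl carbon would separate the two, and a chain ending in an amine would probe the position further.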